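Amino ester series: cytotoxicity notes toward compound 3

The compounds below may be only part of what the source reports. "The series", "measured", "known", "first", "only" and "open" are said of these compounds alone.

compound 1 `CN1CCN(CC(=O)O[C@@H]2C[C@@H]3CC[C@@]2(C)C3(C)C)CC1` — 103000 nM
compound 2 `CCOC(=O)N1CCN(CC(=O)O[C@@H]2C[C@@H]3CC[C@@]2(C)C3(C)C)CC1` — > 852000 nM
compound 3 `CC1(C)[C@H]2CC[C@]1(C)[C@H](OC(=O)CCN1CCCC1)C2` — not yet measured

Among the measured compounds shown here, in an ADME assay on MDCK cells (Canis lupus familiaris) for cytotoxicity, read by MTT assay, with a stated time of 48 h (a higher number here means that more compound is tolerated, a lower number that less compound is tolerated), compound 1 gives 103000 nM, the only plain number among the values shown. For compound 2 the value > 852000 nM is a limit of the assay, not a number. For the measured compounds named here, the single measured step, an at least 8.2-fold higher number from compound 1 to compound 2 (0.91 log units; beyond the scatter), rests on that limit, (the limit of > 852000 nM in this assay, at which 1 of the 2 values shown sits). Compound 3 carries (pyrrolidin-1-yl)methyl in place of 4-methylpiperazin-1-yl on a saturated chain carbon bound to a carbonyl carbon. Going by the values given here, that change differs from the measured one, so no measured step bears on it directly, and no step beyond the scatter in this assay is expected. Compound 3 is estimated at 110000 nM, between 40000 nM and 350000 nM. The expected step is a 1.1-fold higher number from compound 1 to compound 3 (0.03 log units; within the scatter).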

Compound 3, half-maximal cytotoxic concentration: 125000 nM
Compound 3: the middle estimate sits 1.1-fold (0.06 log units) below what was measured, and the stated range covers the measured number.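

In this assay, (pyrrolidin-1-yl)methyl in place of 4-methylpiperazin-1-yl on a saturated chain carbon bound to a carbonyl carbon gives a 1.2-fold higher number from compound 1 to compound 3 (0.08 log units; within the scatter). At this place, then, the ring and the chain both change without a step beyond the scatter, whereas the ethoxycarbonyl change on the ring nitrogen gave a step beyond it. Nothing measured here accounts for this result. Still open, as far as these compounds go, is whether a carboxylic acid, a primary amine or a longer chain carrying the pyrrolidin-1-yl ring would move the number beyond the scatter.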